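Esterifying the acid of compound 2: an expectation

The compounds below may be only part of what the source reports. "The series", "measured", "known", "first", "only" and "open" are said of these compounds alone.

Measured compounds:
compound 1 `Cc1cc(C(=O)N2CCCCc3ccccc32)ccc1CNC(=O)Nc1c(F)cccc1F`, 2.1 nM
compound 2 `Cc1cc(C(=O)N2CCCCc3ccccc32)ccc1CNC(=O)NCC(=O)O`, 180 nM

In a functional assay on HEK293 cells for agonist activity at Vasopressin V2 receptor (Homo sapiens), read by a luciferase reporter and cAMP accumulation (on this read-out higher numbers stand for an effect only at larger amounts of compound and lower numbers for an effect already at smaller amounts), compound 2 gives 180 nM, the highest of the two numbers measured; its nearest neighbour is compound 1, which in this assay gives 2.1 nM. Within the data shown here, the one measured step, an 86-fold higher number from compound 1 to compound 2 (1.93 log units; beyond the scatter), concerns the exchange of a 2,6-difluorophenyl group for carboxymethyl on an amide-type nitrogen.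

Compound 3 `COC(=O)CNC(=O)NCc1ccc(C(=O)N2CCCCc3ccccc32)cc1C` differs from compound 2 in a different way: methyl in place of hydrogen on an oxygen next to a carbonyl group, on an oxygen next to a carbonyl group whose other neighbour is the carbonyl carbon; read one bond further out, carboxy becomes methoxycarbonyl. Among the measured compounds shown here, no measured step covers this change, and the large step from compound 1 to compound 2 does not speak to it. The estimate for compound 3 is therefore close to compound 2, with a step of a 2.0-fold lower number from compound 2 to compound 3 (0.30 log units; within the scatter) expected and a wide range: 90 nM, between 25 nM and 350 nM.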

Compound 3, half-maximal effective concentration: 37 nM
Compound 3: middle estimate off by 2.4-fold (0.39 log units), on the high side; the range from low to high includes it.
By their numbers in this assay, from the lowest: compound 1; then compound 3; then compound 2.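

At this oxygen, methyl in place of hydrogen moves the result by more than the scatter: this assay shows a 4.9-fold lower number from compound 2 to compound 3 (0.69 log units; beyond the scatter), so a free carboxy group is not required for agonist activity at this position. The change recovers only part of the ground lost with carboxymethyl, however, as (methoxycarbonyl)methyl still leaves an 18-fold higher number from compound 1 to compound 3 (1.25 log units; beyond the scatter), and 2,6-difluorophenyl keeps the lowest number of the three groups. Nothing available here explains either step.

The compounds shown leave open whether the gain is specific to methyl or would also appear with ethyl on this oxygen, or with a primary amide in place of methoxycarbonyl. They also leave open how a longer chain carrying the same methoxycarbonyl would compare.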